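The source may report more compounds than this note shows. Statements on the series, on what has been measured and on what is new or still open speak of the compounds shown alone.

Compounds measured in a functional assay on BGC-823 cells (Homo sapiens) for cytotoxicity, read by MTT assay; a lower number here means a stronger inhibitor, a higher number a weaker inhibitor:

Compound 1, `Cc1nc(Nc2ccc(Cl)cc2)sc1C(=O)/C=C/c1ccccc1`: > 25000 nM
Compound 2, `COc1cc(/C=C/C(=O)c2sc(Nc3ccc(Cl)cc3)nc2C)cc(OC)c1OC`: > 25000 nM
Compound 3, `Cc1nc(Nc2cccc(Cl)c2)sc1C(=O)/C=C/c1ccccc1`: > 25000 nM

In this assay compound 1 gives > 25000 nM, which is a limit of the assay and not a number. Compound 2 likewise gives > 25000 nM, a limit. Compound 3 gives > 25000 nM, again a limit. The step that the two limits leave unreadable from compound 1 to compound 3 therefore cannot be read, since both values sit at the limit of > 25000 nM in this assay, at which 3 of the 3 values shown sit. The change behind it is 3-chlorophenyl in place of 4-chlorophenyl on a nitrogen on an aromatic ring. The difference between the cores of compound 1 and compound 2 is not broken down here.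

Compound 4, `COc1cc(/C=C/C(=O)c2sc(Nc3cccc(Cl)c3)nc2C)cc(OC)c1OC`, has not been measured. It differs from compound 2 by 3-chlorophenyl in place of 4-chlorophenyl on a nitrogen on an aromatic ring, the same kind of change as from compound 1 to compound 3. Because compound 2 gives > 25000 nM, a limit, the step that the limit leaves unreadable from compound 2 to compound 4 is expected to stay unreadable. Compound 4 is estimated at 35000 nM (range 12000 nM to 120000 nM), most likely reported only as a limit.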

Compound 4, half-maximal inhibitory concentration: 11600 nM
Beside the measured number, compound 4's estimate is 3.0-fold (0.48 log units) above it, outside the stated range (below it).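

In this assay, 3-chlorophenyl in place of 4-chlorophenyl gives an at least 2.1-fold lower number from compound 2 to compound 4 (0.33 log units; beyond the scatter), so on the core of compound 2 the change moves the result off the limit to a measured number. On the core of compound 1 the same change cannot be read, because both compounds of that pair stay at a limit of the assay: the limit of > 25000 nM in this assay, at which 3 of the 4 values shown sit. The result therefore does not show that the change carries from one core to the other, since any gain on the core of compound 1 would stay hidden, and the size of the step on the core of compound 2 is only a bound.

The compounds shown leave open what an amine or a carboxylic acid in place of the chlorine would do on either core.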